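Methoxy for chloro on the aryl ether of compound 1

This account rests on a few compounds, and the source may have more. Where it says the series, first, only, none or still open, it means among the compounds named here.

Measured so far:
compound 1, `NC1=NC2(CCSCC2)N(OCCCOc2ccc(Cl)cc2)C(N)=N1`: 580 nM
compound 2, `NC1=NC2(CCOCC2)N(OCCCOc2ccc(Cl)cc2Cl)C(N)=N1`: 70 nM
compound 3, `NC1=NC2(CCOCC2)N(OCCCOc2ccc(Br)cc2)C(N)=N1`: 280 nM

In a functional assay on A549 cells (Homo sapiens) for antiproliferative activity, read by MTT assay, with a stated time of 72 h (a higher number here means a weaker inhibitor, a lower number a stronger inhibitor), compound 1 gives the highest number of the three, with compound 3 nearest and compound 2 furthest. Among the measured compounds shown here, the one change between measured compounds that differ in a single place is a 4.0-fold higher number from compound 2 to compound 3 (0.60 log units; beyond the scatter), a shift in the halogen pattern of the aryl group on the oxygen of the saturated chain. Compound 1 and compound 3 differ in two places, the ring heteroatom of the shared core and the halogen, so their values are only noted side by side.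

Compound 4, `COc1ccc(OCCCON2C(N)=NC(N)=NC23CCSCC3)cc1`, is not yet measured. It differs from compound 1 by methoxy in place of chloro on an aromatic carbon. For the measured compounds named here, no measured step removes a halogen from this aryl group or introduces methoxy, so the only bearing is indirect: the halogen change from compound 2 to compound 3 moved the number by a modest amount, and every measured compound carries a halogen. A step of similar size, toward a higher number, is expected, a 1.7-fold higher number from compound 1 to compound 4 (0.24 log units; within the scatter). Compound 4 is estimated at 1000 nM, within 400 nM to 2500 nM.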

Compound 4, half-maximal inhibitory concentration: 240 nM
For compound 4 the middle estimate is 4.2-fold (0.62 log units) above the measured one; measured number below the stated range.
By their numbers in this assay, from the lowest: compound 2; then compounds 4 and 3 (each within the scatter of the next); then compound 1.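

In this assay, the change to 4-methoxyphenyl from 4-chlorophenyl gives a 2.4-fold lower number from compound 1 to compound 4 (0.38 log units; beyond the scatter), a step beyond the scatter. Among the compounds shown here, this is the first evidence that a halogen on this aromatic carbon, para to a large group, is not needed to retain activity: a non-halogen group carrying one hydrogen-bond acceptor is accepted here, and the number goes down rather than up. The reading holds for this one pair only, on the core of compound 1. No available evidence accounts for the step, so its cause stays unassigned.

On these data alone, it remains open whether the same exchange gives a step of like direction and size on the core of compound 3, which carries oxygen in its ring where compound 1 carries sulfur. Also open, as far as these compounds go, is how this position responds to an unsubstituted phenyl, an amine or a carboxylic acid.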